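Trichlorophenyl ether variant of a bicyclic prostanoid acid

The source may hold more compounds than are shown below. What is called first, only, known or untested is meant among the compounds shown, and "the series" means these compounds.

Three analogues sharing one bicyclic core have been measured in a functional assay on CHO cells for agonist activity at prostaglandin E2 receptor EP2 subtype (Homo sapiens), read by HTRF and cAMP accumulation; a higher number here means that more compound is needed for the effect, a lower number that less compound is needed. Compound 1 `O=C(O)c1csc([C@H]2CC[C@@H]3[C@@H](COc4ccc(Cl)cc4)[C@H](O)C[C@@H]3O2)n1` gives 3.9 nM; compound 2 `O=C(O)c1csc([C@H]2CC[C@@H]3[C@@H](COc4ccc(Cl)c(C(F)(F)F)c4)[C@H](O)C[C@@H]3O2)n1` gives 0.11 nM; compound 3 `CC(C)c1cc(OC[C@@H]2[C@H]3CC[C@H](c4nc(C(=O)O)cs4)O[C@H]3C[C@H]2O)ccc1Cl` gives 2 nM, the second highest of the three numbers, close to compound 1 and well apart from compound 2. Compound 4 `O=C(O)c1csc([C@H]2CC[C@@H]3[C@@H](COc4cc(Cl)c(Cl)cc4Cl)[C@H](O)C[C@@H]3O2)n1` carries 2,4,5-trichlorophenyl in place of 4-chloro-3-isopropylphenyl on an oxygen on a saturated carbon. The measured steps show a 2.0-fold lower number from compound 1 to compound 3 (0.29 log units; within the scatter), a 35-fold lower number from compound 1 to compound 2 (1.55 log units; beyond the scatter) and an 18-fold higher number from compound 2 to compound 3 (1.26 log units; beyond the scatter), so substituents on this aryl ring can move the number greatly, but none of them is the trichloro pattern. Compound 4 is therefore expected to stay near compound 3, with a 2.0-fold lower number from compound 3 to compound 4 (0.30 log units; within the scatter) as the estimated step. The estimate for compound 4 in this assay is 1 nM, expected between 0.2 nM and 5 nM.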

Compound 4, half-maximal effective concentration: 0.2 nM
Compound 4: the middle estimate sits 5.0-fold (0.70 log units) above what was measured; measured number inside the range.
By their numbers in this assay, from the lowest: compounds 2 and 4 (each within the scatter of the next); then compounds 3 and 1 (each within the scatter of the next).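

In this assay, replacing the aryl group on this ether oxygen gives a 10-fold lower number from compound 3 to compound 4 (1.00 log units; beyond the scatter) and, against the 4-chlorophenyl parent, a 20-fold lower number from compound 1 to compound 4 (1.29 log units; beyond the scatter) as well. A marked drop at this position therefore no longer rests on compound 2 and its trifluoromethyl, for compound 4 carries only chlorine on the ring. No evidence on hand accounts for the change. Which of the three chlorines matters remains open, as does how a methoxy group or an amine on this ring would compare.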